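The source may report more compounds than this note shows. Statements on the series, on what has been measured and on what is new or still open speak of the compounds shown alone.

Measured in an ADME assay on J774 cells (Mus musculus) for cytotoxicity; on this read-out lower numbers stand for an effect already at smaller amounts and higher numbers for an effect only at larger amounts of compound:
Compound 1 `COC(=O)c1c[nH]c2cc(OCCOc3ccccc3)c(OC)cc2c1=O`: > 20000 nM
Compound 2 `COC(=O)c1c[nH]c2cc(Oc3ccccc3)ccc2c1=O`: 9120 nM
Compound 3 `COC(=O)c1c[nH]c2ccc(OC)cc2c1=O`: 6180 nM

Compound 1 stands at > 20000 nM, which is a limit of the assay and not a number. Compound 2 and compound 3 give numbers within the usual scatter of each other. Compound 4 `CCc1cc2c(=O)c(C(=O)OC)c[nH]c2cc1OCCOc1ccccc1` carries ethyl in place of methoxy on an aromatic carbon, ortho to a large group (ethyl in place of methoxy on an aromatic carbon). Going by the values given here, no measured pair shows this change. In this assay no step beyond the scatter is expected, in either direction. The estimated step is a number no higher from compound 1 to compound 4 (the limit leaves the size open). For compound 4 the expected value is 20000 nM, with an estimated range from 8000 nM to 40000 nM.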

Compound 4, half-maximal effective concentration: > 20000 nM
Compound 4 was reported as a limit; the forecaster's own chance of this, stated with the estimate: 55%; the middle value sits exactly at the limit.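

Going by these compounds alone, compound 1 and compound 4 both stand at a limit of the assay and not at a number, so no step between them can be read: the limit of > 20000 nM in this assay, at which 2 of the 4 values shown sit.
As far as these compounds go, whether ethyl in place of methoxy on an aromatic carbon shifts the value in either direction stays open.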